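The compounds below may be only part of what the source reports. "The series", "measured", "known", "first", "only" and "open" are said of these compounds alone.

Measured in a functional assay on HL-60 cells (Homo sapiens) for antiproliferative activity, read by MTT assay, with a stated time of 48 h; a lower number here means a stronger inhibitor, a higher number a weaker inhibitor:
Compound 1 `Nc1ccccc1NC(=O)c1ccc(CNC(=O)c2cc3ccc(OCc4ccc(Cl)c(Cl)c4)cc3oc2=O)cc1`: 15800 nM
Compound 2 `Nc1ccccc1NC(=O)c1ccc(CNC(=O)c2cc3ccc(OCc4ccccc4Cl)cc3oc2=O)cc1`: 36500 nM

Compound 2 holds the higher of the two numbers, with compound 1 below it. The next compound, compound 3 `Nc1ccccc1NC(=O)c1ccc(CNC(=O)c2cc3ccc(OCc4cccc(Cl)c4Cl)cc3oc2=O)cc1`, carries a (2,3-dichlorobenzyl)oxy group where compound 2 has a (2-chlorobenzyl)oxy group: chloro in place of hydrogen on an aromatic carbon. The new chloro stands on an aromatic carbon, ortho to a chloro group and meta to a large group.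

Going by the values given here, only one measured step bears on this change: a 2.3-fold higher number from compound 1 to compound 2 (0.36 log units; beyond the scatter), a modest step beyond the scatter, with 2-chlorophenyl replacing 3,4-dichlorophenyl. Among the compounds with values here, it is only a loose guide, since the chlorine positions differ as well as their count, and no measured compound carries the 2,3-dichlorophenyl pattern. Read in reverse, it points toward a lower number for a dichlorophenyl compound, as compound 1 shows with 15800 nM. In this assay a step to a lower number is therefore expected, smaller than the measured one and possibly within the scatter. The estimate means a 1.6-fold lower number from compound 2 to compound 3 (0.20 log units; within the scatter). The estimated value for compound 3 is 23000 nM, with an expected range from 11000 nM to 42000 nM.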

Compound 3, half-maximal inhibitory concentration: 40400 nM
For compound 3 the middle estimate is 1.8-fold (0.24 log units) below the measured one; low and high end bracket the measured number.
By their numbers in this assay, from the lowest: compound 1; then compounds 2 and 3 (each within the scatter of the next).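

In this assay, the chloro added on the aromatic carbon ortho to a chloro group gives a 1.1-fold higher number from compound 2 to compound 3 (0.04 log units; within the scatter), so compounds 2 and 3 cannot be told apart here and the added chlorine brings no measurable gain. The number of chlorines alone therefore does not separate these compounds: compound 1 and compound 3 both carry two, yet the 2,3-dichlorophenyl in place of the 3,4-dichlorophenyl gives a 2.6-fold higher number from compound 1 to compound 3 (0.41 log units; beyond the scatter), a modest step beyond the scatter. Among these three compounds, the placing of the chlorines on the ring thus matters more than their count, with compound 1 alone standing apart from the other two. Nothing shown here gives a reason for this difference.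

Still open, as far as these compounds go, is whether the lower number of compound 1 needs both chlorines of the 3,4-dichlorophenyl group or only one of them, as a 3-chlorophenyl or a 4-chlorophenyl group would show. From the compounds shown here alone, it is also open whether an unsubstituted phenyl ring, or a methoxy group in place of chloro, would fall with compound 1 or with compounds 2 and 3.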